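This account rests on a few compounds, and the source may have more. Where it says the series, first, only, none or still open, it means among the compounds named here.

Compound 3 `Fc1ccc(Cc2ccc3c(NCCCNCc4ccco4)ccnc3c2)cc1` gives 23 10^-6 cm/s in an ADME assay for permeability, using PAMPA, with a stated time of 30 min, at pH 7.4 (on this read-out higher numbers stand for higher permeability and lower numbers for lower permeability), the lowest of the three values measured. Compound 1 `COc1ccccc1Oc1ccc2c(NCCCNCc3ccco3)ccnc2c1` gives 317 10^-6 cm/s and compound 2 `Fc1ccc(Oc2ccc3c(NCCCNCc4ccco4)ccnc3c2)cc1` gives 317 10^-6 cm/s in this assay. The steps of a 14-fold lower number from compound 1 to compound 3 (1.14 log units; beyond the scatter) and a 14-fold lower number from compound 2 to compound 3 (1.14 log units; beyond the scatter) are both large, whereas the step of no change at the digits printed from compound 1 to compound 2 (within the scatter) stays within the scatter. Compound 4 `c1coc(CNCCCNc2ccnc3cc(CC4CCCCC4)ccc23)c1` differs from compound 3 in one place: cyclohexyl in place of 4-fluorophenyl on a saturated chain carbon bound to an aromatic carbon. For the measured compounds named here, no measured step exchanges an aromatic ring for a non-aromatic one; the two large steps put a benzyl in place of a phenoxy group on an aromatic carbon, and the step that swaps one aromatic ring for another lies within the scatter. The step of a 1.3-fold higher number from compound 3 to compound 4 (0.12 log units; within the scatter) is therefore expected to remain within the scatter. Compound 4 is estimated at 30 10^-6 cm/s, with a range from 10 10^-6 cm/s to 90 10^-6 cm/s.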

Compound 4, apparent permeability in the ADME assay: 23 10^-6 cm/s
The estimate for compound 4 lay 1.3-fold (0.12 log units) above the measured number; low and high end bracket the measured number.
By their numbers in the ADME assay, from the lowest: compounds 3 and 4 (each within the scatter of the next); then compounds 1 and 2 (each within the scatter of the next).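

In the ADME assay, the exchange of an aromatic ring for a non-aromatic one on this saturated chain carbon gives no change at the digits printed from compound 3 to compound 4 (within the scatter), so here the 4-fluorophenyl ring can give way to cyclohexyl with no change beyond the scatter. The large gap to the phenoxy compounds remains with cyclohexylmethyl on the aromatic carbon: a 14-fold lower number from compound 2 to compound 4 (1.14 log units; beyond the scatter) and a 14-fold lower number from compound 1 to compound 4 (1.14 log units; beyond the scatter). In a physicochemical assay for acid dissociation, compound 3 gives 9.47 and compound 4 gives 9.47, the same number.

Nothing available accounts for these numbers. As far as these compounds go, whether a cyclohexyloxy group on that aromatic carbon would stand with compound 2 or with compound 4 in the ADME assay remains open.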